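Cyclopentyloxy replaces 3-aminophenyl on a triple-bonded carbon

This account rests on a few compounds, and the source may have more. Where it says the series, first, only, none or still open, it means among the compounds named here.

Measured in an ADME assay on HepG2 cells (Homo sapiens) for cytotoxicity, read by MTT assay, with a stated time of 24 h; on this read-out lower numbers stand for higher toxicity in this test and higher numbers for lower toxicity in this test:
Compound 1 `Cc1ccc(C#Cc2c([N+](=O)[O-])nc3n2CC(C)O3)cc1`: 4440 nM
Compound 2 `CC1Cn2c(nc([N+](=O)[O-])c2C#CC2CC2)O1`: 14800 nM
Compound 3 `CC1Cn2c(nc([N+](=O)[O-])c2C#Cc2cccc(N)c2)O1`: 8300 nM

The three compounds share one core and differ only in the group on a triple-bonded carbon. Compound 3 lies within the scatter of both other compounds, as a 1.9-fold higher number from compound 1 to compound 3 (0.27 log units; within the scatter) and a 1.8-fold lower number from compound 2 to compound 3 (0.25 log units; within the scatter) show. Within the data shown here, only one measured step goes beyond the scatter, namely a 3.3-fold higher number from compound 1 to compound 2 (0.52 log units; beyond the scatter), with cyclopropyl in place of 4-methylphenyl.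

Compound 4 `CC1Cn2c(nc([N+](=O)[O-])c2C#COC2CCCC2)O1` keeps the shared core and differs from compound 3 in one place: cyclopentyloxy in place of 3-aminophenyl on a triple-bonded carbon. In words, this is cyclopentyloxy in place of 3-aminophenyl on a triple-bonded carbon. Among the measured compounds shown here, no measured compound carries cyclopentyloxy, so the data give no direct precedent for this group. All three measured steps are swaps at this same place, though, and the largest of them is modest. As far as these compounds go, on that basis, no change beyond the scatter is expected in this assay, and the direction remains open. The expected step is a 1.1-fold higher number from compound 3 to compound 4 (0.04 log units; within the scatter). For compound 4 the estimated value is 9000 nM, with an expected range from 3500 nM to 23000 nM.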

Compound 4, half-maximal cytotoxic concentration: 8350 nM
The estimate for compound 4 lay 1.1-fold (0.03 log units) above the measured number, within the range that was stated.
By their numbers in this assay, from the lowest: compounds 1, 3, 4 and 2 (each within the scatter of the next, the first and the last beyond it).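

In this assay, the change from an aromatic ring carrying an amine to a non-aromatic ring joined through oxygen, which also removes the hydrogen-bond donor counted for 3-aminophenyl, gives no shift beyond the scatter (a 1.0-fold higher number from compound 3 to compound 4 (0.00 log units; within the scatter)). Among these compounds, compound 4 also stays within the scatter of the other two compounds (a 1.8-fold lower number from compound 2 to compound 4 (0.25 log units; within the scatter); a 1.9-fold higher number from compound 1 to compound 4 (0.27 log units; within the scatter)), so it joins the middle of the series and leaves the step from compound 1 to compound 2 as the only one beyond the scatter, which shows that this place on the triple-bonded carbon accepts a wider range of groups than the earlier compounds showed, with little separation among them in this test. Nothing available explains why these different groups give such closely spaced numbers.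

As far as these compounds go, whether a carboxylic acid or a longer chain ending in an amine on the triple-bonded carbon would move the number beyond the scatter stays open. The compounds shown also leave open whether cyclopentyloxy would behave the same way on a core that differs from the shared one.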